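The compounds below may be only part of what the source reports. "The series", "measured", "known", "first", "only" and "open" are said of these compounds alone.

Compound 3, `CCCc1cn(C/C=C(\C)CCC=C(C)C)nn1`, sits second highest of the three numbers in a physicochemical assay for lipophilicity, measured as octanol-water partition; on this read-out higher numbers stand for higher lipophilicity and lower numbers for lower lipophilicity: compound 3 gives 4.5. Compound 1, `COC(=O)c1cn(C/C=C(\C)CCC=C(C)C)nn1`, gives 3.2 in this assay, and the step of a number 1.30 log units higher from compound 1 to compound 3 (beyond the scatter) is large. Compound 2, `CCCCCc1cn(C/C=C(/C)CCC=C(C)C)nn1`, gives 5.45 in this assay, a value that stands higher than that of compound 3, and compound 2 carries the pentyl chain that compound 4 also carries, on the other geometry of the double bond.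

Compound 4, `CCCCCc1cn(C/C=C(\C)CCC=C(C)C)nn1`, differs from compound 3 in one place: ethyl in place of hydrogen on a saturated chain carbon, three bonds along the chain from an aromatic carbon. No measured step shows this exact change; the only step shown, from compound 1 to compound 3, exchanges a different group and tells little about chain lengthening. The values of compound 2 and compound 3 are the nearest guide to what the pentyl chain brings.

An upward step a number 0.90 log units higher from compound 3 to compound 4 (beyond the scatter) in this assay is therefore expected, beyond the scatter. For compound 4 the expected value in this assay is 5.4, with a range of 4.9 to 5.9.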

Compound 4, partition coefficient: 5.45
The estimate for compound 4 lay 0.05 log units below the measured number; low and high end bracket the measured number.
By their numbers in this assay, from the lowest: compound 1; then compound 3; then compounds 2 and 4 (each within the scatter of the next).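

In this assay, the change from propyl to pentyl on the aromatic carbon reads as a number 0.95 log units higher from compound 3 to compound 4 (beyond the scatter), so lengthening the chain at this position moves the number beyond the scatter, and pentyl in place of methoxycarbonyl reads as a number 2.25 log units higher from compound 1 to compound 4 (beyond the scatter). For the compounds shown here, the geometry of the double bond, which the earlier compounds could not isolate, reads as no change at the digits printed from compound 2 to compound 4 (within the scatter). That comparison speaks to the double bond alone: the fact that compounds 2 and 4 differ only in the configuration as drawn.

As far as these compounds go, whether a longer chain such as heptyl would carry the number further at this position, and how a chain ending in an amine or a carboxylic acid would read, stays open. The compounds shown offer a pair of double-bond geometries only with pentyl, so whether the same holds with propyl or methoxycarbonyl also stays open.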